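A few compounds are considered here, and "the series" means these few. Any claim that something is new, unique, unknown or untested is made for them only; others in the source may bear on it.

Compound 1 `CC(C)Cn1nc(C(=O)N[C@H]2COc3ccccc3N(C)C2=S)nc1Cc1ccccc1` stands lowest of the three compounds measured in a functional assay on HT-29 cells (Homo sapiens) for inhibition, read by luminescence and CellTiter-Glo, with a stated time of 24 h (a lower number here means that less compound is needed, a higher number that more compound is needed for the effect), where compound 1 gives 1230 nM. Compound 2 `CN1C(=S)[C@@H](NC(=O)c2nc(Cc3ccccc3)n(CCCCC#N)n2)COc2ccccc21` gives 2680 nM and compound 3 `CN1C(=S)[C@@H](NC(=O)c2nc(Cc3ccccc3)n(CC3CCOC3)n2)COc2ccccc21` gives 4420 nM. The measured steps are a 2.2-fold higher number from compound 1 to compound 2 (0.34 log units; beyond the scatter), a 3.6-fold higher number from compound 1 to compound 3 (0.56 log units; beyond the scatter) and a 1.6-fold higher number from compound 2 to compound 3 (0.22 log units; within the scatter). Compound 4 `CN1C(=S)[C@@H](NC(=O)c2nc(Cc3ccccc3)n(-c3ncccn3)n2)COc2ccccc21` differs from compound 1 at the same aromatic nitrogen: pyrimidin-2-yl in place of isobutyl on an aromatic nitrogen. Going by the values given here, both measured changes at that nitrogen raised the number beyond the scatter, by modest amounts, so a modest rise is expected again, with the caveat that no measured compound carries an aromatic ring there. Compound 4 is therefore estimated at 2600 nM, within 900 nM to 7500 nM, which means an expected step of a 2.1-fold higher number from compound 1 to compound 4 (0.33 log units; beyond the scatter).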

Compound 4, half-maximal effective concentration: 3970 nM
For compound 4 the middle estimate is 1.5-fold (0.18 log units) below the measured one, within the range that was stated.
By their numbers in this assay, from the lowest: compound 1; then compounds 2, 4 and 3 (each within the scatter of the next).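

In this assay, pyrimidin-2-yl, the first aromatic ring placed directly on this aromatic nitrogen, gives a 3.2-fold higher number from compound 1 to compound 4 (0.51 log units; beyond the scatter), so isobutyl remains the group with the lowest number. Compound 4 does not separate from the two chain-linked replacements, with a 1.1-fold lower number from compound 3 to compound 4 (0.05 log units; within the scatter) and a 1.5-fold higher number from compound 2 to compound 4 (0.17 log units; within the scatter), so a directly attached aromatic ring and these saturated chains cannot be told apart here. Nothing available accounts for this result.

On these data alone, whether a plain phenyl ring, a cyclopropyl group or a chain ending in an amine on this nitrogen would fall in the same range or below compound 1 stays open.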